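Cutting the Aryl Arm Down to a Methyl Amide

A few compounds are considered here, and "the series" means these few. Any claim that something is new, unique, unknown or untested is made for them only; others in the source may bear on it.

Measured compounds:
compound 1 `Cc1ccc(/C=N/NC(=O)c2oc3nc(-c4cccs4)cc(C(F)(F)F)c3c2N)cc1`: 19800 nM
compound 2 `Nc1c(C(=O)N/N=C/c2ccc(Br)cc2)oc2nc(-c3cccs3)cc(C(F)(F)F)c12`: 6100 nM
compound 3 `Cc1ccc(/C=N/NC(=O)c2oc3nc(-c4ccccc4)cc(C(F)(F)F)c3c2N)cc1`: 8900 nM

All three were tested in a functional assay on HepG2 cells (Homo sapiens) for antiproliferative activity, read by MTT assay; a lower number here means a stronger inhibitor, a higher number a weaker inhibitor. Compound 3 gives 8900 nM, the second highest of the three numbers; it sits within the scatter of compound 2 and is separated from compound 1 by a 2.2-fold lower number from compound 1 to compound 3 (0.35 log units; beyond the scatter). Compound 4 `CNC(=O)c1oc2nc(-c3ccccc3)cc(C(F)(F)F)c2c1N` has not yet been measured. The change from compound 3 is one carbon atom in place of a group of 9 heavy atoms (8 carbon, 1 nitrogen; one six-membered aromatic ring of carbon only), on an amide-type nitrogen. Neither measured step resembles this one: a 3.2-fold lower number from compound 1 to compound 2 (0.51 log units; beyond the scatter) and a 2.2-fold lower number from compound 1 to compound 3 (0.35 log units; beyond the scatter) were both modest and touched groups that survive in compound 4, so they give no direct guide. Removing the whole aromatic ring is a larger change than either, and compound 4 is expected to be weaker, by an estimated 3.4-fold higher number from compound 3 to compound 4 (0.53 log units; beyond the scatter). Compound 4 is therefore estimated at 30000 nM, in the range 8000 nM to 100000 nM.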

Compound 4, half-maximal inhibitory concentration: 41200 nM
The estimate for compound 4 lay 1.4-fold (0.14 log units) below the measured number; the range from low to high includes it.
By their numbers in this assay, from the lowest: compounds 2 and 3 (each within the scatter of the next); then compound 1; then compound 4.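

In this assay, cutting the arm on the amide-type nitrogen down to a methyl gives a 4.6-fold higher number from compound 3 to compound 4 (0.67 log units; beyond the scatter), showing that the number responds to this position as well as to the groups changed earlier. This single step cannot separate the contribution of the six-membered aromatic ring from that of the double bond outside it. No measurement shown here explains the shift.

As far as these compounds go, it remains open whether a shorter arm, such as a benzyl group, or a longer alkyl chain on this nitrogen would bring the number back towards that of compound 3.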